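The compounds below may be only part of what the source reports. "The series", "measured", "known", "first", "only" and "open" are said of these compounds alone.

In an assay (strain Wistar) for inhibition of Hormone-sensitive lipase (Rattus norvegicus), read by spectrophotometry (on this read-out higher numbers stand for weaker inhibition and lower numbers for stronger inhibition), compound 1 `Cc1c(C(C)C)c(=O)on1C(=O)N1CCC(c2ccccc2)CC1` gives 12 nM, compound 2 `Cc1c(CC(C)C)c(=O)on1C(=O)N1CCC(c2ccccc2)CC1` gives 10 nM, and compound 3 `Cc1c(C2CCCC2)c(=O)on1C(=O)N1CCC(c2ccccc2)CC1` gives 24 nM. Compound 3 has the highest number of the three, yet a 2.0-fold higher number from compound 1 to compound 3 (0.30 log units; within the scatter), while a 2.4-fold higher number from compound 2 to compound 3 (0.38 log units; beyond the scatter). Compound 4 `COCCc1c(C)n(C(=O)N2CCC(c3ccccc3)CC2)oc1=O` is not yet measured; it differs from compound 3 in one place: 2-methoxyethyl in place of cyclopentyl on an aromatic carbon. All measured steps exchange the group on that same aromatic carbon, and alongside the two above, a 1.2-fold lower number from compound 1 to compound 2 (0.08 log units; within the scatter), so every change there so far has stayed small. None of them introduces a hydrogen-bond acceptor, so the guidance is limited to the finding that this position tolerates change. The expectation for compound 4 is therefore a small step, a 1.0-fold higher number from compound 3 to compound 4 (0.02 log units; within the scatter), probably within the scatter. Compound 4 is expected to give 25 nM, between 8 nM and 80 nM.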

Compound 4, half-maximal inhibitory concentration: 11 nM
Beside the measured number, compound 4's estimate is 2.3-fold (0.36 log units) above it; the range from low to high includes it.
By their numbers in this assay, from the lowest: compounds 2, 4, 1 and 3 (each within the scatter of the next, the first and the last beyond it).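

Compound 4's 2-methoxyethyl group is the first group shown on this aromatic carbon that carries a hydrogen-bond acceptor, and it sits within the scatter of both open-chain compounds (a 1.1-fold lower number from compound 1 to compound 4 (0.04 log units; within the scatter); a 1.1-fold higher number from compound 2 to compound 4 (0.04 log units; within the scatter)). Against the cyclopentyl ring the change goes beyond the scatter (a 2.2-fold lower number from compound 3 to compound 4 (0.34 log units; beyond the scatter)), so compound 3 differs from compound 2 and compound 4, though not from compound 1. Nothing available gives a reason for these steps.

The compounds shown leave open how an amine or a carboxylic acid on this carbon would behave. They also leave open whether a longer chain ending in methoxy would behave like 2-methoxyethyl.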